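The source may hold more compounds than are shown below. What is called first, only, known or untested is meant among the compounds shown, and "the series" means these compounds.

Compound 2 `Cn1cc2nc(CCCc3ccccc3)nc(N)c2n1` stands highest of the two measured compounds in an assay on CHO cells for displacement of a labelled ligand from adenosine receptor A3 (Homo sapiens), read by scintillation counting, with a stated time of 60 min, tested at 1 uM (a lower number here means less inhibition, a higher number more inhibition at the concentration tested (going by the name of the read-out)), where compound 2 gives 30%. Compound 1 `COc1ccccc1-n1cc2nc(CCCc3ccccc3)nc(N)c2n1` gives 6% in this assay. For the measured compounds named here, the only measured step, a number 24 percentage points higher from compound 1 to compound 2 (beyond the scatter), bears directly on compound 3 `Nc1nc(CCCc2ccccc2)nc2cn(-c3ccccc3O)nc12`, which carries 2-hydroxyphenyl in place of methyl on an aromatic nitrogen. A six-membered aromatic ring on that nitrogen returns, as in compound 1, though with a hydroxyl rather than a methoxy group. The expected step of a number 18 percentage points lower from compound 2 to compound 3 (beyond the scatter) therefore runs downward, roughly undoing the earlier gain. Compound 3 is estimated at 12%, with a range from 0% to 35%.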

Compound 3, a percentage reported as inhibition, at one concentration (the size of the read-out at that concentration, not a potency): 5%
Estimate against measurement, compound 3: 7 percentage points above, and the stated range covers the measured number.
By their numbers in this assay, from the lowest: compounds 3 and 1 (each within the scatter of the next); then compound 2.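

Placing 2-hydroxyphenyl in place of methyl on the aromatic nitrogen gives a clear drop (a number 25 percentage points lower from compound 2 to compound 3 (beyond the scatter)), so in this assay the lower reading seen with 2-methoxyphenyl also holds for a second substituted phenyl group. Putting hydrogen in place of methyl on the oxygen changes little (a number 1 percentage points lower from compound 1 to compound 3 (within the scatter)), so the hydroxyl and methoxy versions cannot be told apart here. Still open, from the compounds shown here alone, is how an unsubstituted phenyl, an ethyl or a longer alkyl chain on that nitrogen would read. Nothing available explains the difference between these groups and methyl.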